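Removing the 4-(dimethylamino)phenyl group of compound 2

The source may hold more compounds than are shown below. What is called first, only, known or untested is meant among the compounds shown, and "the series" means these compounds.

In a functional assay on UACC-62 cells (Homo sapiens) for cytotoxicity, read by sulforhodamine B assay (a lower number here means a stronger inhibitor of growth, a higher number a weaker inhibitor of growth), compound 1 `CC1=CC[C@@H]([C@@](C)(O)CCCC(C)(C)NC(=S)N/N=C\c2ccccc2)CC1` gives 12700 nM. Compound 2 `CC1=CC[C@@H]([C@@](C)(O)CCCC(C)(C)NC(=S)N/N=C\c2ccc(N(C)C)cc2)CC1` is reported only as a limit, > 100000 nM. Compound 3 `CC1=CC[C@@H]([C@@](C)(O)CCCC(C)(C)NC(=S)N/N=C\c2ccccc2Cl)CC1` differs from it as follows: 2-chlorophenyl in place of 4-(dimethylamino)phenyl on a carbon with a double bond to nitrogen. Among the measured compounds shown here, the one measured step bearing on this change is an at least 7.8-fold higher number from compound 1 to compound 2 (0.89 log units; beyond the scatter), and it came with the dimethylamino group that now leaves. For the measured compounds named here, no measured step covers the chlorine. A move to a lower number of similar size is therefore expected, returning close to compound 1. The estimated step is an at least 10-fold lower number from compound 2 to compound 3 (1.00 log units; beyond the scatter). For compound 3 the expected value is 10000 nM, with an estimated range of 3000 nM to 40000 nM.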

Compound 3, concentration for 50% growth inhibition: 53300 nM
Estimate against measurement, compound 3: 5.3-fold (0.73 log units) below; measured number outside the range, above it.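

Chloro in place of hydrogen also weakens growth inhibition in this assay, with a 4.2-fold higher number from compound 1 to compound 3 (0.62 log units; beyond the scatter), so the loss seen on this ring does not belong to dimethylamino alone. The swap of groups reads as an at least 1.8-fold lower number from compound 2 to compound 3 (0.27 log units; that floor lies within the scatter), and this is only a floor. The value of compound 2 is a limit and not a number, so the true size of that step stays unknown: the limit of > 100000 nM in this assay, at which 1 of the 3 values shown sits.

The compounds shown leave open whether a group such as fluoro, methoxy or a carboxylic acid on the phenyl ring could bring the number below that of compound 1, 12700 nM.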